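The source may hold more compounds than are shown below. What is called first, only, known or untested is meant among the compounds shown, and "the series" means these compounds.

In a functional assay on MDA-MB-435S cells (Homo sapiens) for cytotoxicity, read by MTT assay, with a stated time of 72 h (a lower number here means a stronger inhibitor, a higher number a weaker inhibitor), compound 1 `O=c1c(CSc2cc(=O)c3ccccc3s2)coc2ccccc12` gives 1700 nM. Compound 2 `Cc1cc(C)n2nc(SCc3cc(=O)c4cc(Cl)ccc4o3)nc2n1` reaches only > 25000 nM in this assay, which is a limit of the assay rather than a number. Compound 3 `Nc1nnc(SCc2cc(=O)c3ccccc3o2)s1` likewise stops at > 25000 nM, again a limit rather than a number. Compound 2 thus stands at the limit of > 25000 nM in this assay, at which 2 of the 3 values shown sit, so its true value is not known. Compound 4 `Cc1ccc2oc(CSc3nc4nc(C)cc(C)n4n3)cc(=O)c2c1` has not yet been measured in this assay; it differs from compound 2 by methyl in place of chloro on an aromatic carbon. For the measured compounds named here, no measured pair here isolates this change, so nothing in the data points to a shift in either direction beyond the usual scatter. Compound 4 is therefore expected to stay near the limit, with an estimated step of a number no higher from compound 2 to compound 4 (the limit leaves the size open) and an estimated value of 25000 nM, between 10000 nM and 60000 nM.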

Compound 4, half-maximal inhibitory concentration: > 25000 nM
Compound 4: no number, only a limit; the forecaster's own chance of this, stated with the estimate: 70%; the middle value lies on the limit itself.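

Compound 2 and compound 4 both give only a limit, not a number, so no step can be read for methyl in place of chloro. From the compounds shown here alone, whether that change alters their activity at all stays open.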